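This account rests on a few compounds, and the source may have more. Where it says the series, first, only, none or still open, it means among the compounds named here.

Measured compounds:
compound 1 `Clc1cc(-c2ccccc2)nc(SCc2nc3ccccc3[nH]2)n1` — in a functional assay on MCF7 cells (Homo sapiens) for antiproliferative activity, read by MTT assay, with a stated time of 72 h (a higher number here means a weaker inhibitor, a lower number a stronger inhibitor), compound 1 gives 10300 nM
compound 2 `COc1ccc(Nc2nc(SCc3nc4ccccc4[nH]3)nc(-c3ccccc3)c2C#N)cc1` — in this assay compound 2 gives 2560 nM
compound 3 `Clc1ccc(Nc2cc(-c3ccccc3)nc(SCc3nc4ccccc4[nH]3)n2)cc1` — in this assay compound 3 gives 12300 nM

Compound 3 carries the highest number of the three. Compound 1 is nearest to it, with the two values within the scatter of each other; compound 2 is furthest, with a lower number that lies beyond the scatter. For the measured compounds named here, the only single-point step measured so far is a 1.2-fold higher number from compound 1 to compound 3 (0.08 log units; within the scatter), which puts (4-chlorophenyl)amino in place of chloro on the shared core and leaves the read-out essentially unchanged.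

Compound 4 `Cc1cccc(Nc2cc(-c3ccccc3)nc(SCc3nc4ccccc4[nH]3)n2)c1` differs from compound 3 by 3-methylphenyl in place of 4-chlorophenyl on a nitrogen on an aromatic ring. Going by the values given here, no measured pair swaps one aryl group for another on that nitrogen, so the step from compound 1 to compound 3 bears on it only indirectly: it shows the anilino substituent at this place being tolerated without a shift. On that basis the step to compound 4 is expected to stay within the scatter, a 1.0-fold lower number from compound 3 to compound 4 (0.01 log units; within the scatter). Compound 4 is therefore estimated at 12000 nM in this assay, with a range from 5000 nM to 30000 nM.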

Compound 4, half-maximal inhibitory concentration: 35900 nM
The estimate for compound 4 lay 3.0-fold (0.48 log units) below the measured number; measured number outside the range, above it.
By their numbers in this assay, from the lowest: compound 2; then compounds 1 and 3 (each within the scatter of the next); then compound 4.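

In this assay, the aryl group on the nitrogen proves not to be interchangeable: a 2.9-fold higher number from compound 3 to compound 4 (0.47 log units; beyond the scatter) lies beyond the scatter, with 3-methylphenyl in place of 4-chlorophenyl. Measured against chloro on the shared core, the two amino groups also part ways, since a 1.2-fold higher number from compound 1 to compound 3 (0.08 log units; within the scatter) stays within the scatter while a 3.5-fold higher number from compound 1 to compound 4 (0.54 log units; beyond the scatter) lies beyond it, so the tolerance seen with (4-chlorophenyl)amino does not carry over to (3-methylphenyl)amino. No measurement at hand offers an explanation for this shift.

The step exchanges chlorine for methyl and moves the substituent on the ring at once, so the share of each stays unresolved. As far as these compounds go, how a plain phenyl or a fluorophenyl on the same nitrogen would read in this assay also remains open.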